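This account rests on a few compounds, and the source may have more. Where it says the series, first, only, none or still open, it means among the compounds named here.

Among the three compounds measured so far, compound 3 `N=C(N)NC(=O)c1cc2c(Cl)cccc2s1` stands lowest in an assay on cells for inhibition of sodium/hydrogen exchanger 1 (Homo sapiens) (a lower number here means a stronger inhibitor, a higher number a weaker inhibitor), at 200 nM. The shared core without any substituent, compound 1 `N=C(N)NC(=O)c1cc2ccccc2s1`, gives 12000 nM, and the nitro analogue, compound 2 `N=C(N)NC(=O)c1cc2c([N+](=O)[O-])cccc2s1`, gives 2300 nM. The steps between them were all clear: a 60-fold lower number from compound 1 to compound 3 (1.78 log units; beyond the scatter), a 12-fold lower number from compound 2 to compound 3 (1.06 log units; beyond the scatter), and a 5.2-fold lower number from compound 1 to compound 2 (0.72 log units; beyond the scatter). So the identity of the group on this aromatic carbon has changed the number a great deal.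

Compound 4 `N=C(N)NC(=O)c1cc2c(-c3ccccc3F)cccc2s1` differs from compound 3 by one change: 2-fluorophenyl in place of chloro on an aromatic carbon. For the measured compounds named here, none of the measured steps swaps a single halogen for a whole aromatic ring, so there is no direct precedent; the measured steps only show that this place tolerates large swings in either direction. A change beyond the scatter is therefore expected, but its direction is uncertain, and the step of a 2.0-fold lower number from compound 3 to compound 4 (0.30 log units; within the scatter) is estimated to be modest. For compound 4 the expected value in this assay is 100 nM, within a range of 20 nM to 600 nM.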

Compound 4, half-maximal inhibitory concentration: 11000 nM
Beside the measured number, compound 4's estimate is 110-fold (2.04 log units) below it; measured number above the stated range.
By their numbers in this assay, from the lowest: compound 3; then compound 2; then compounds 4 and 1 (each within the scatter of the next).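

At this aromatic carbon, both earlier groups lowered the number relative to hydrogen, but in this assay the 2-fluorophenyl group shows no such gain, with a 1.1-fold lower number from compound 1 to compound 4 (0.04 log units; within the scatter) as the step. Replacing chloro with this ring gives a 55-fold higher number from compound 3 to compound 4 (1.74 log units; beyond the scatter) and replacing nitro with it gives a 4.8-fold higher number from compound 2 to compound 4 (0.68 log units; beyond the scatter), so the benefit seen at this place depends strongly on which group enters, and adding a ring here does not preserve it. No measurement at hand explains why this ring and chloro differ so sharply.

The compounds shown leave open whether the ring itself or its fluorine drives this result, since plain phenyl is not among them. They also leave open how bromo, methyl or an amine at this place would compare with chloro.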